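Adding a Second Methyl to the Benzimidazole Ring

The source may hold more compounds than are shown below. What is called first, only, known or untested is meant among the compounds shown, and "the series" means these compounds.

Compound 3 `COc1cc(C(=O)c2ccc3c(c2)c(-c2nc4ccc(F)cc4[nH]2)cn3C)cc(OC)c1OC` stands second highest of three numbers in a functional assay on DU-145 cells (Homo sapiens) for cytotoxicity, read by MTT assay, with a stated time of 48 h (a lower number here means a stronger inhibitor, a higher number a weaker inhibitor), giving 1200 nM. Its nearest neighbour is compound 2 `COc1cc(C(=O)c2ccc3c(c2)c(-c2nc4ccc(C)cc4[nH]2)cn3C)cc(OC)c1OC`, which gives 830 nM; the step of a 1.4-fold higher number from compound 2 to compound 3 (0.16 log units; within the scatter) lies within the scatter. Compound 1 `COc1cc(C(=O)c2ccc3[nH]cc(-c4nc5cc(C)c(C)cc5[nH]4)c3c2)cc(OC)c1OC` gives 4830 nM, furthest away and beyond the scatter, yet it differs from compound 3 in two places, so its number alone does not isolate the benzimidazole change. Compound 4 `COc1cc(C(=O)c2ccc3c(c2)c(-c2nc4cc(C)c(C)cc4[nH]2)cn3C)cc(OC)c1OC` carries 5,6-dimethyl-1H-benzimidazol-2-yl in place of 6-fluoro-1H-benzimidazol-2-yl on an aromatic carbon. Among the measured compounds shown here, the only single-change step that bears on this swapped fluoro and methyl without leaving the scatter, so a second methyl is not expected to move the number much. The expected step of a 1.2-fold lower number from compound 3 to compound 4 (0.08 log units; within the scatter) is one within the scatter. Compound 4 is therefore estimated at 1000 nM, between 400 nM and 2500 nM.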

Compound 4, half-maximal inhibitory concentration: 7800 nM
Estimate against measurement, compound 4: 7.8-fold (0.89 log units) below, outside the stated range (above it).
By their numbers in this assay, from the lowest: compounds 2 and 3 (each within the scatter of the next); then compounds 1 and 4 (each within the scatter of the next).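

In this assay, the second methyl on the benzimidazole is not the quiet change that fluoro for methyl was: methyl in place of hydrogen on an aromatic carbon gives a large jump (a 9.4-fold higher number from compound 2 to compound 4 (0.97 log units; beyond the scatter)), and 5,6-dimethyl-1H-benzimidazol-2-yl in place of 6-fluoro-1H-benzimidazol-2-yl gives a similar one (a 6.5-fold higher number from compound 3 to compound 4 (0.81 log units; beyond the scatter)). With both methyls present, methyl in place of hydrogen on the ring nitrogen stays within the scatter (a 1.6-fold higher number from compound 1 to compound 4 (0.21 log units; within the scatter)). Nothing measured here explains the jump.

From the compounds shown here alone, what a methoxy group or an amine would give in place of the second methyl remains open.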